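Adding a methyl to the propoxy chain of compound 2

The source may report more compounds than this note shows. Statements on the series, on what has been measured and on what is new or still open speak of the compounds shown alone.

Measured in a functional assay on L1210 (1565) cells (Mus musculus) for cytotoxicity; on this read-out lower numbers stand for an effect already at smaller amounts and higher numbers for an effect only at larger amounts of compound:
- Compound 1 `CC(C)Oc1cc(-c2ccccc2)nc2ccccc12`: > 10 ug/mL (a limit)
- Compound 2 `CCCOc1cc(-c2ccccc2)nc2ccccc12`: > 10 ug/mL (a limit)
- Compound 3 `Oc1cc(-c2ccccc2)nc2cc(F)ccc12`: 0.16 ug/mL

Compound 2 stands only at a limit of this assay, > 10 ug/mL. That is the limit of > 10 ug/mL in this assay, at which 2 of the 3 values shown sit. Compound 3 gives a real number, but it differs from compound 2 in more than one place.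

Compound 4 `CC(C)COc1cc(-c2ccccc2)nc2ccccc12` follows from compound 2 by one change: methyl in place of hydrogen on a saturated chain carbon bound to two saturated chain carbons, which turns propoxy into isobutoxy. Among the compounds with values here, the one measured step that bears on this is a step that the two limits leave unreadable from compound 1 to compound 2, and no size can be read from it. With no size to carry over, a change beyond the scatter is not expected, and a further reading at the limit is likely. The expected step is a step that the limit leaves unreadable from compound 2 to compound 4. For compound 4 the estimate is 15 ug/mL, with an expected range of 6 ug/mL to 40 ug/mL.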

Compound 4, half-maximal effective concentration: > 10 ug/mL
Compound 4: only a limit was reported (the forecaster's own chance of this, stated with the estimate: 85%); the middle value does not contradict the limit.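

Within the data shown here, compound 1, compound 2 and compound 4 all stop at the same limit in this assay, so no step among them can be read: the limit of > 10 ug/mL in this assay, at which 3 of the 4 values shown sit. The compounds shown leave open whether propyl, isopropyl and isobutyl on the oxygen differ in effect at all.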